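This account rests on a few compounds, and the source may have more. Where it says the series, first, only, none or still open, it means among the compounds named here.

Compound 1 `O=c1nc(-c2ccccc2)c2cc(-c3cccnc3)ccc2[nH]1`: > 50000 nM in an ADME assay on L6 cells (Rattus norvegicus) for cytotoxicity, read by fluorescence and resazurin assay, with a stated time of 72 h (a lower number here means that less compound is needed, a higher number that more compound is needed for the effect), a limit of the assay.
Compound 2 `O=c1nc(-c2ccccc2)c2cc(-c3cccc(F)c3)ccc2[nH]1`: 23000 nM.
Compound 3 `CNC(=O)c1cccc(-c2ccc3[nH]c(=O)nc(-c4ccccc4)c3c2)c1`: > 50000 nM, again a limit of the assay.

Going by the values given here, compound 2 thus stands as the only true number in this assay, while the other two values sit at the limit of > 50000 nM in this assay, at which 2 of the 3 values shown sit. Compound 4 `O=c1nc(-c2ccccc2)c2cc(N3CCNCC3)ccc2[nH]1` differs from compound 2 by piperazin-1-yl in place of 3-fluorophenyl on an aromatic carbon. Among the compounds with values here, two measured steps touch the same place. The step of an at least 2.1-fold lower number from compound 1 to compound 2 (0.33 log units; beyond the scatter) and the step of an at least 2.1-fold higher number from compound 2 to compound 3 (0.33 log units; beyond the scatter) both show that replacing or altering the 3-fluorophenyl group there moves the number up to the limit. Piperazin-1-yl is expected to behave likewise, so a step of a 2.2-fold higher number from compound 2 to compound 4 (0.34 log units; beyond the scatter) is expected, most likely ending at a limit again. Compound 4 is therefore estimated at 50000 nM, with a range from 20000 nM to 150000 nM.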

Compound 4, half-maximal effective concentration: > 25000 nM
Compound 4 ended at the assay's limit; the forecaster's own chance of this, stated with the estimate: 60%; the middle value lies beyond the limit too.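

Going by these compounds alone, a non-aromatic ring now sits on this aromatic carbon for the first time, and in this assay piperazin-1-yl in place of 3-fluorophenyl gives an at least 1.0-fold higher number from compound 2 to compound 4 (0.03 log units; that floor lies within the scatter), so no rise beyond the scatter can be claimed for this change. The value of compound 4 is a limit and not a number: the limit of > 25000 nM in this assay, at which 1 of the 4 values shown sits. The step between compound 1 and compound 4 cannot be read, as both values are limits. Still open, on these data alone, is how far compound 4 truly lies from compound 2. Also open, as far as these compounds go, is whether morpholin-4-yl or an open-chain amine at this place would give a true number rather than a limit.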